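The source may report more compounds than this note shows. Statements on the series, on what has been measured and on what is new or still open speak of the compounds shown alone.

Measured compounds:
- compound 1 `O=C(Nc1ccccc1Cl)C(Cl)Cl`: compound 1 gives "not determined" (no result reported)
- compound 2 `O=C(Nc1cccc(Cl)c1)C(Cl)Cl`: compound 2 gives 44500 nM

Going by the values given here, in a functional assay on Bel-7402 cells (Homo sapiens) for antiproliferative activity, read by MTT assay, with a stated time of 72 h (on this read-out higher numbers stand for weaker inhibition and lower numbers for stronger inhibition), compound 2 holds the only number so far; compound 1 has no result, so there is no step between measured compounds from which a direction for added or moved chloro groups could be read. Compound 3 `O=C(Nc1cc(Cl)ccc1Cl)C(Cl)Cl` differs from compound 2 by chloro in place of hydrogen on an aromatic carbon. With nothing measured on either side of this change, the step is expected to stay within the usual scatter, or at most to run slightly toward stronger inhibition, so the expected step is a 1.5-fold lower number from compound 2 to compound 3 (0.17 log units; within the scatter). Compound 3 is estimated to give about 30000 nM in this assay, with a range from 10000 nM to 90000 nM, and this expectation rests on compound 2 alone and its value 44500 nM.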

Compound 3, half-maximal inhibitory concentration: 18200 nM
Beside the measured number, compound 3's estimate is 1.6-fold (0.22 log units) above it; low and high end bracket the measured number.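

In this assay, going by these compounds alone, chloro in place of hydrogen on an aromatic carbon, ortho to a group of 6 heavy atoms and para to a chloro group, gives a 2.4-fold lower number from compound 2 to compound 3 (0.39 log units; beyond the scatter) as the first readable step. The step is modest but beyond the usual scatter, so this position accepts a second chloro group on the ring with stronger, not weaker, inhibition. Nothing at hand bears on why the number moves.

Compound 1 has no result, so steps involving it cannot be read. Whether the gain belongs to chloro itself stays open, since the compounds shown do not tell how a methyl group, a methoxy group, an amine or a carboxylic acid on this same aromatic carbon would compare.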